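Bis-benzylidene pyranone series: effect of removing ring chlorines

The compounds below may be only part of what the source reports. "The series", "measured", "known", "first", "only" and "open" are said of these compounds alone.

Measured so far:
compound 1 `O=C1/C(=C/c2ccccc2F)COC/C1=C\c1ccc(Cl)cc1Cl` — 7900 nM
compound 2 `COc1ccc(OC)c(/C=C2\COC/C(=C\c3ccccc3F)C2=O)c1` — 8700 nM

In a functional assay on A549 cells (Homo sapiens) for cytotoxicity, read by MTT assay, with a stated time of 72 h (a lower number here means a stronger inhibitor, a higher number a weaker inhibitor), compound 1 gives 7900 nM and compound 2 gives 8700 nM; the two values sit within the scatter of each other, so neither stands apart. Compound 3 `O=C1/C(=C/c2ccccc2)COC/C1=C\c1ccccc1F` is not yet measured. It differs from compound 1 by phenyl in place of 2,4-dichlorophenyl on a double-bonded chain carbon bound to a double-bonded ring carbon. Within the data shown here, no measured pair shows the loss of both chlorines, so the direction rests on expectation alone; a modest weakening is expected, a 1.5-fold higher number from compound 1 to compound 3 (0.18 log units; within the scatter), possibly within the scatter. Compound 3 is estimated at 12000 nM, with a range from 4000 nM to 40000 nM.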

Compound 3, half-maximal inhibitory concentration: 17600 nM
The estimate for compound 3 lay 1.5-fold (0.17 log units) below the measured number, and the stated range covers the measured number.
By their numbers in this assay, from the lowest: compounds 1 and 2 (each within the scatter of the next); then compound 3.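

In this assay, among these compounds, phenyl in place of 2,4-dichlorophenyl on a double-bonded chain carbon bound to a double-bonded ring carbon gives a 2.2-fold higher number from compound 1 to compound 3 (0.35 log units; beyond the scatter) as the first readable step at this position. The step is modest but beyond the scatter, so the two groups can be told apart here. Nothing measured bears on the cause of this step. Open, as far as these compounds go, is whether a single chlorine, as in 4-chlorophenyl, would carry the same step. Also open, from the compounds shown here alone, is how a ring bearing an amine or a carboxylic acid would compare at this position.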